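A few compounds are considered here, and "the series" means these few. Any claim that something is new, unique, unknown or untested is made for them only; others in the source may bear on it.

Compound 1 has the structure `CCCOc1ccc(C[C@@H](Cc2ccccc2)C(=O)O)cc1CNC(=O)c1ccc(-c2ccccc2)cc1`. In a physicochemical assay for solubility, read by HPLC, in phosphate buffer, measured as thermodynamic solubility, with a stated time of 48 h, at pH 7.2 (a lower number here means a less soluble compound, a higher number a more soluble compound), compound 1 gives < 1 ug/mL, which is a limit of the assay rather than a number; compound 1 thus sits at the limit of < 1 ug/mL in this assay, at which 1 of the 2 values shown sits. Compound 2, with the structure `CCCOc1ccc(C[C@@H](Cc2ccccc2)C(=O)O)cc1CNC(=O)c1ccc(-c2ccccn2)cc1`, gives in this assay a value of 17 ug/mL. Among the measured compounds shown here, the only measured step, an at least 17-fold higher number from compound 1 to compound 2 (1.23 log units; beyond the scatter), is a different kind of change and does not show what a methyl does at this place. Compound 3 has the structure `CCCOc1ccc(C[C@@H](Cc2ccccc2)C(=O)O)cc1CNC(=O)c1ccc(-c2ccccc2C)cc1`. Compared with compound 1 it carries methyl in place of hydrogen on an aromatic carbon. For the measured compounds named here, with no measured step of this kind to lean on, the expectation rests on compound 1 standing at < 1 ug/mL in this assay. The step that the limit leaves unreadable from compound 1 to compound 3 is therefore expected to stay within the scatter. Compound 3 is estimated to give 0.7 ug/mL, expected to lie between 0.2 ug/mL and 2.5 ug/mL.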

Compound 3, solubility: < 1 ug/mL
Compound 3: no number, only a limit; the forecaster's own chance of this, stated with the estimate: 75%; the middle value does not contradict the limit.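

In this assay compound 3 gives < 1 ug/mL as a limit and not as a number. Its step from compound 1 cannot be read, so what the methyl does here stays hidden, and the limit now holds most of the compounds shown: the limit of < 1 ug/mL in this assay, at which 2 of the 3 values shown sit. What can be read is an at least 17-fold lower number from compound 2 to compound 3 (1.23 log units; beyond the scatter) when 2-methylphenyl stands in place of pyridin-2-yl, so a methyl on the carbon-only ring does not bring back the higher number that compound 2 shows.

Whether a methyl shifts the number at all remains hidden behind the limit in these compounds. Also open, from the compounds shown here alone, is how a methyl on the pyridin-2-yl ring of compound 2 would read, and how an amine or a hydroxyl on the phenyl ring of compound 1 would read.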